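This account rests on a few compounds, and the source may have more. Where it says the series, first, only, none or still open, it means among the compounds named here.

Measured in a physicochemical assay for lipophilicity, using the shake flask method, measured as octanol-water partition, at pH 7.4; a lower number here means a more polar compound, a higher number a more lipophilic compound:
compound 1, `COc1cc(/C=C/C(=O)Nc2ccccc2)ccc1OCCCN1CCCC1`, gives 1.57
compound 2, `COc1cc(/C=C/C(=O)Nc2ccccc2)ccc1OCCCCCN(C)C`, gives 1.61
compound 3, `COc1cc(/C=C/C(=O)Nc2ccccc2)ccc1OCCCCCCN1CCCC1`, gives 1.76
Not yet measured: compound 4, `COc1cc(/C=C/C(=O)Nc2ccccc2)ccc1OCCCCCCCCN(C)C`.

The change from compound 1 to compound 2 is 2-(dimethylamino)ethyl in place of pyrrolidin-1-yl on a saturated chain carbon, three bonds along the chain from an oxygen on an aromatic ring. In this assay it gave a number 0.04 log units higher from compound 1 to compound 2 (within the scatter). The same kind of change takes compound 3 to compound 4: 2-(dimethylamino)ethyl in place of pyrrolidin-1-yl on a saturated chain carbon, six bonds along the chain from an oxygen on an aromatic ring. The two cores differ by 3-(pyrrolidin-1-yl)propyl in place of pyrrolidin-1-yl on a saturated chain carbon, three bonds along the chain from an oxygen on an aromatic ring. The place is not the same word for word: in the first pair the saturated chain carbon sits three bonds along the chain from an oxygen on an aromatic ring, in the second pair six bonds along the chain from an oxygen on an aromatic ring. Within the measured set, the two further steps are both within the scatter: a number 0.15 log units higher from compound 2 to compound 3 (within the scatter) and a number 0.19 log units higher from compound 1 to compound 3 (within the scatter).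

For compound 3 to compound 4 a step of about the earlier size is expected, a number 0.04 log units higher from compound 3 to compound 4 (within the scatter), resting on the first pair because of a number 0.04 log units higher from compound 1 to compound 2 (within the scatter). Compound 4 is therefore estimated at 1.8, within 1.5 to 2.1.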

Compound 4, partition coefficient: 1.74
Estimate against measurement, compound 4: 0.06 log units above; the range from low to high includes it.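

In this assay, 2-(dimethylamino)ethyl in place of pyrrolidin-1-yl gave a number 0.04 log units higher from compound 1 to compound 2 (within the scatter) with the saturated chain carbon three bonds along the chain from an oxygen on an aromatic ring, and a number 0.02 log units lower from compound 3 to compound 4 (within the scatter) with that carbon six bonds along the chain from an oxygen on an aromatic ring, so on these two cores the change stays within the scatter. The wider steps, a number 0.13 log units higher from compound 2 to compound 4 (within the scatter) and a number 0.17 log units higher from compound 1 to compound 4 (within the scatter), are also within the scatter, so the chains shown are not told apart in this assay and no step here gives a size to carry over. Two pairs do not show that the change would stay this small on other cores, and nothing measured speaks to what lies behind these numbers.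

From the compounds shown here alone, whether the same holds with piperidin-1-yl or morpholin-4-yl in place of pyrrolidin-1-yl, or with a carboxylic acid in place of the amine, remains open. Going by these compounds, a longer chain than that of compound 4 also remains open, as it is unknown whether a step beyond the scatter would then appear.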